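Cyclohexyl Urea Expected to Improve on Ethyl(methyl) Analogue

The source may hold more compounds than are shown below. What is called first, only, known or untested is meant among the compounds shown, and "the series" means these compounds.

Compound 1, `CCNC(=O)N1CCN(C(=S)SCc2cn(Cc3ccccc3F)nn2)CC1`, gives > 128000 nM in a functional assay on SMMC-7721 cells (Homo sapiens) for cytotoxicity, read by MTT assay, with a stated time of 72 h (on this read-out higher numbers stand for weaker inhibition and lower numbers for stronger inhibition), which is a limit of the assay and not a number.
Compound 2, `CC(C)NC(=O)N1CCN(C(=S)SCc2cn(Cc3ccccc3F)nn2)CC1`, gives 7130 nM in this assay.
Compound 3, `CCN(C)C(=O)N1CCN(C(=S)SCc2cn(Cc3ccccc3F)nn2)CC1`, gives 19700 nM in this assay.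

Of the two numbers shown, compound 3 has the higher one; the step of a 2.8-fold higher number from compound 2 to compound 3 (0.44 log units; beyond the scatter) is a modest rise. Compound 4, `O=C(NC1CCCCC1)N1CCN(C(=S)SCc2cn(Cc3ccccc3F)nn2)CC1`, differs by cyclohexylamino in place of ethyl(methyl)amino on a carbonyl carbon. Among the compounds with values here, the steps that bear on this are an at least 17-fold lower number from compound 1 to compound 2 (1.25 log units; beyond the scatter), where a branched alkyl on the urea nitrogen helped greatly, and a 2.8-fold higher number from compound 2 to compound 3 (0.44 log units; beyond the scatter), where replacing that nitrogen-bound hydrogen cost a little. Compound 4 keeps the hydrogen and carries a bulkier branched group, so a lowering step a 3.9-fold lower number from compound 3 to compound 4 (0.60 log units; beyond the scatter) is expected. Compound 4 is therefore estimated at 5000 nM, between 1500 nM and 20000 nM.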

Compound 4, half-maximal inhibitory concentration: > 128000 nM
Compound 4: a limit, no number; the forecaster's own chance of this, stated with the estimate: 5%; middle value at least 25-fold (1.40 log units) from the limit.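

On the urea nitrogen, keeping the amide hydrogen and a branched group is not enough: cyclohexyl in place of isopropyl gives an at least 17-fold higher number from compound 2 to compound 4 (1.25 log units; beyond the scatter), so the gain seen with isopropyl does not carry over to this ring. Cyclohexylamino also does worse than ethyl(methyl)amino, with an at least 6.4-fold higher number from compound 3 to compound 4 (0.81 log units; beyond the scatter). The result for compound 4 is a limit and not a number, the same limit as for compound 1: the limit of > 128000 nM in this assay, at which 2 of the 4 values shown sit.

Those two limits leave the step between compound 1 and compound 4 unreadable. Going by these compounds, whether a smaller ring on that nitrogen, such as cyclopropyl or cyclopentyl, would hold the activity of compound 2 remains open.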